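A few compounds are considered here, and "the series" means these few. Any claim that something is new, unique, unknown or untested is made for them only; others in the source may bear on it.

In a functional assay on LNCaP cells (Homo sapiens) for antiproliferative activity (a higher number here means a weaker inhibitor, a lower number a stronger inhibitor), compound 2 `Cn1ncc(Cl)c1-c1cc(C(=O)N[C@@H]2CN[C@H](CCN3CCC(O)CC3)C[C@H]2c2ccc(Cl)c(Cl)c2)oc1Cl` gives 1140 nM, the highest of the three measured numbers and so the weakest inhibitor among them. Compound 3 `CC(=O)NCC[C@@H]1C[C@@H](c2ccc(F)c(F)c2)[C@H](NC(=O)c2cc(-c3c(Cl)cnn3C)c(Cl)o2)CN1` gives 130 nM, and compound 1 `Cn1ncc(Cl)c1-c1cc(C(=O)N[C@@H]2CN[C@H](CCNS(C)(=O)=O)C[C@H]2c2ccc(F)c(F)c2)oc1Cl` gives 50 nM.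

Compound 4 `Cn1ncc(Cl)c1-c1cc(C(=O)N[C@@H]2CN[C@H](CCN3CCCCC3)C[C@H]2c2ccc(Cl)c(Cl)c2)oc1Cl` differs from compound 2 in one place: hydrogen in place of hydroxy on a saturated ring carbon. This is hydrogen in place of hydroxy on a saturated ring carbon, which turns 4-hydroxypiperidin-1-yl into piperidin-1-yl.

Among the measured compounds shown here, no measured pair shows this change. For the measured compounds named here, the only measured single change is a 2.6-fold higher number from compound 1 to compound 3 (0.41 log units; beyond the scatter), with acetyl in place of methylsulfonyl on an amine nitrogen. That modest step involves different groups, so it offers only a loose guide to size and none to direction. A small step is therefore expected in this assay, probably within the scatter, with a slight lean to a lower number since compound 2 sits highest at 1140 nM. The expected change is a 1.4-fold lower number from compound 2 to compound 4 (0.15 log units; within the scatter). For compound 4 the estimated value is 800 nM, with an expected range from 280 nM to 2300 nM.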

Compound 4, half-maximal inhibitory concentration: 1780 nM
Compound 4: middle estimate off by 2.2-fold (0.35 log units), on the low side; the measured number falls inside the stated range.
By their numbers in this assay, from the lowest: compound 1; then compound 3; then compounds 2 and 4 (each within the scatter of the next).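

In this assay, taking the hydroxy off the 4-hydroxypiperidin-1-yl group to leave piperidin-1-yl gives a 1.6-fold higher number from compound 2 to compound 4 (0.19 log units; within the scatter), so this pair cannot be told apart. At this saturated ring carbon, three ring bonds from the ring nitrogen, the hydroxy can therefore be lost with no change that stands clear of the ordinary spread of repeat measurements, though this rests on a single pair. No supporting measurement is available to explain this result.

Still open, on these data alone, is how an amino group, a methoxy group or a carboxylic acid on the same ring carbon would read in this assay. Also open, as far as these compounds go, is whether a morpholin-4-yl group, with a ring oxygen in place of that carbon, would stay as close to compound 4.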